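The source may report more compounds than this note shows. Statements on the series, on what has been measured and on what is new or still open speak of the compounds shown alone.

Measured so far:
Compound 1 `NC(=O)CCCSC[C@H](NC(=O)OCc1ccccc1)C(=O)Nc1ccccc1` — 11%
Compound 2 `CNC(=O)CCCSC[C@H](NC(=O)OCc1ccccc1)C(=O)Nc1ccccc1` — "not active" (no number reported)

Going by the values given here, compound 1 carries the only number reported in an assay for inhibition of NAD-dependent protein deacylase sirtuin-6 (Homo sapiens), read by HPLC, with stated times of 15 min and 1 h, tested at 333 uM; a higher number here means more inhibition at the concentration tested (going by the name of the read-out), a lower number less inhibition; compound 2, which differs from it at the amide nitrogen, was returned without a number, only as "not active" (no number reported). So compound 1 stands alone as a weak but measurable entry, and nothing in the shown data reaches beyond the usual scatter.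

Compound 3 `O=C(O)CNC(=O)CCCSC[C@H](NC(=O)OCc1ccccc1)C(=O)Nc1ccccc1` has not been measured. It differs from compound 1 by carboxymethyl in place of hydrogen on an amide-type nitrogen. Among the compounds with values here, no measured pair shows this change, so no size for its step is known. With compound 1 already low and compound 2 reported only as inactive, the step from compound 1 to compound 3 is expected to be small, if anything downward, and within the scatter: a number 5 percentage points lower from compound 1 to compound 3 (within the scatter). Compound 3 is therefore estimated to give 6%, in a range from 0% to 18%.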

Compound 3, a percentage reported as inhibition, at one concentration (the size of the read-out at that concentration, not a potency): 53%
Estimate against measurement, compound 3: 47 percentage points below; the measured number lies above the stated range.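

At this amide-type nitrogen, a number 42 percentage points higher from compound 1 to compound 3 (beyond the scatter) in this assay when carboxymethyl takes the place of hydrogen, so the position can carry a substituent with a large gain. The earlier pair gave no such reading: compound 2, with methyl on the same nitrogen, stands as "not active" (no number reported) without a number, and its step from compound 1 cannot be read. Nothing shown accounts for the gain.

The compounds shown leave open whether the carboxylic acid is needed for this gain, since no methyl ester or primary amide in its place appears among them. They also leave open how a longer chain ending in a carboxylic acid, or a chain ending in an amine, would behave at this nitrogen.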